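Ester Capping of the Cinnamic Acid in a Cytotoxicity Series

A few compounds are considered here, and "the series" means these few. Any claim that something is new, unique, unknown or untested is made for them only; others in the source may bear on it.

Three acids of one shared core have been measured in a functional assay on EA.hy 926 cells (Homo sapiens) for cytotoxicity, read by MTT assay, with stated times of 24 h and 12 h, tested at 25 uM; a lower number here means a weaker effect, a higher number a stronger effect of the compound at the concentration tested. Compound 1 `Cc1nc(C)c(C(=O)Oc2ccccc2/C=C/C(=O)O)nc1C` gives 61.8%, compound 2 `COc1ccc(/C=C/C(=O)O)cc1OC(=O)c1nc(C)c(C)nc1C` gives 128%, and compound 3 `COc1cc(/C=C/C(=O)O)cc(OC)c1OC(=O)c1nc(C)c(C)nc1C` gives 24%. Compound 2 stands highest of the three numbers; its nearest neighbour is compound 1, whose number is lower by an amount beyond the scatter, and the furthest is compound 3, lower still and again beyond the scatter. No two of these compounds differ in a single place, so no measured step can be read from them.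

Compound 4 `CCOC(=O)/C=C/c1ccc(OC)c(OC(=O)c2nc(C)c(C)nc2C)c1` has not yet been measured in this assay. It differs from compound 2 in one place: ethyl in place of hydrogen on an oxygen next to a carbonyl group. The change sits on an oxygen next to a carbonyl group, and read one bond further out it turns carboxy into ethoxycarbonyl. Nothing measured in this series shows what that change does to the read-out, so the expectation rests only on the high number of compound 2 at 128% and on the general spread of the three acids. A moderate downward step is expected, although one no larger than the scatter would not surprise. For compound 4 the estimated value in this assay is 95%, within 50% to 140%. The estimate means a step of a number 33 percentage points lower from compound 2 to compound 4 (beyond the scatter).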

Compound 4, a percentage reported as activity, at one concentration (the size of the read-out at that concentration, not a potency): 60.1%
For compound 4 the middle estimate is 34.9 percentage points above the measured one; low and high end bracket the measured number.
By their numbers in this assay, from the lowest: compound 3; then compounds 4 and 1 (each within the scatter of the next); then compound 2.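

In this assay, among these compounds, ethyl in place of hydrogen on an oxygen next to a carbonyl group, which turns carboxy into ethoxycarbonyl, gives a number 67.9 percentage points lower from compound 2 to compound 4 (beyond the scatter) as the first single-place step that can be read. Among the compounds shown here, this position therefore matters for the read-out: on this one pair, the change from 2-carboxyethenyl to 2-(ethoxycarbonyl)ethenyl takes the number down by a large step, whereas the earlier compounds could show only that three acids spread widely, with no change tied to any one place. No measured finding is available that would account for this step.

What the compounds shown leave open is whether the size of the step follows the ethyl group itself or any replacement of that hydrogen; a methyl ester, a longer chain such as butyl, or an amide at the same carbonyl would separate the two. Also open, on these data alone, is whether ethoxycarbonyl in place of carboxy would move the number in the same direction on the cores of compound 1 and compound 3.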